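The source may hold more compounds than are shown below. What is called first, only, known or untested is meant among the compounds shown, and "the series" means these compounds.

Within the data shown here, compound 2 `COc1ccc(-c2cccc(NC(=O)CCc3cccc4c3B(O)OC4)c2)cc1` is the more potent of the two compounds measured so far in an ADME assay on WI-38 cells (Homo sapiens) for cytotoxicity, read by MTT assay, with a stated time of 72 h (a higher number here means a weaker inhibitor, a lower number a stronger inhibitor), where compound 2 gives 1400 nM. Its nearest neighbour is compound 1 `O=C(CCc1cccc2c1B(O)OC2)Nc1ccccc1`, which in this assay gives 30000 nM. Among the measured compounds shown here, the only measured step runs between these two: a 21-fold lower number from compound 1 to compound 2 (1.33 log units; beyond the scatter), brought about by 4-methoxyphenyl in place of hydrogen on an aromatic carbon.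

Compound 3 `CSc1ccc(-c2cccc(NC(=O)CCc3cccc4c3B(O)OC4)c2)cc1` keeps everything of compound 2 except one change: methylsulfanyl in place of methoxy on an aromatic carbon. For the measured compounds named here, no measured step concerns this exchange on the aromatic ring; the step from compound 1 to compound 2 shows only what the whole 4-methoxyphenyl adds, not what a swap within its para substituent does. In the absence of a step that bears on it, the expectation for this assay is a change that stays within the scatter, with no direction to be read from the data.

Compound 3 is therefore estimated at 1400 nM in this assay, within a range of 500 nM to 4000 nM. This estimate means a step of no change at the digits printed from compound 2 to compound 3 (within the scatter), expected to lie within the scatter.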

Compound 3, half-maximal inhibitory concentration: 3800 nM
Compound 3: the middle estimate sits 2.7-fold (0.43 log units) below what was measured; the measured number falls inside the stated range.
By their numbers in this assay, from the lowest: compound 2; then compound 3; then compound 1.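

The exchange of methoxy for methylsulfanyl, on an aromatic carbon para to a large group, gives a 2.7-fold higher number from compound 2 to compound 3 (0.43 log units; beyond the scatter) in this assay, so this substituent matters in its own right, a contribution the earlier step could not separate from that of the whole 4-methoxyphenyl. The lowering of the number does not depend on methoxy alone, since the added ring bearing methylsulfanyl still gives a 7.9-fold lower number from compound 1 to compound 3 (0.90 log units; beyond the scatter), although compound 3 stands above compound 2 in the order of numbers. No measurement shown explains why the two groups differ, and no cause can be given for this step.

As far as these compounds go, with only methoxy and methylsulfanyl at this carbon, it remains open how much of the effect comes from the added ring itself and how much from its substituent, which a plain phenyl would help to settle, and whether a hydroxy group, a dimethylamino group or a carboxylic acid at the same place would give a lower or a higher number. From the compounds shown here alone, it also remains open whether a longer chain on the oxygen or sulfur would carry the difference between these two groups further.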